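A nitro group on compound 2, at the limit

A few compounds are considered here, and "the series" means these few. Any claim that something is new, unique, unknown or untested is made for them only; others in the source may bear on it.

Measured in a functional assay on Jurkat cells (Homo sapiens) for antiproliferative activity, read by MTT assay, with a stated time of 72 h; a lower number here means a stronger inhibitor, a higher number a weaker inhibitor:
Compound 1 `COc1cccc(-c2ncnn2-c2cc(OC)c(OC)c(OC)c2)c1`: > 10000 nM, a limit
Compound 2 `COc1cc(-n2ncnc2-c2ccccc2)cc(OC)c1OC`: > 10000 nM, a limit

Compound 2 stands only at a limit, as does the other measured compound, so the record holds just (the limit of > 10000 nM in this assay, at which 2 of the 2 values shown sit). Compound 3 `COc1cc(-n2ncnc2-c2cccc([N+](=O)[O-])c2)cc(OC)c1OC` differs from compound 2 by nitro in place of hydrogen on an aromatic carbon. Within the data shown here, the one measured step, a step that the two limits leave unreadable from compound 1 to compound 2, gives no size to carry over. Among the measured compounds shown here, no step of known size or direction is therefore expected in this assay, and a further limit is the likeliest result. Compound 3 is estimated at 10000 nM, with an expected range of 3000 nM to 30000 nM. The estimated step is a number no higher from compound 2 to compound 3 (the limit leaves the size open).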

Compound 3, half-maximal inhibitory concentration: > 10000 nM
Compound 3: a limit, no number; the forecaster's own chance of this, stated with the estimate: 75%; the middle value sits exactly at the limit.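

No step among compound 1, compound 2 and compound 3 can be read, since each result is only a limit: the limit of > 10000 nM in this assay, at which 3 of the 3 values shown sit.

The compounds shown leave open how strong each one actually is, and whether a methoxy or nitro group in place of hydrogen changes that at all.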